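Nitro to isopropoxy on the benzyl ring of compound 3

The source may report more compounds than this note shows. Statements on the series, on what has been measured and on what is new or still open speak of the compounds shown alone.

Measured compounds:
compound 1, `COc1cccc(OC)c1OCCNCCOc1ccccc1OCc1ccccc1Cl`, in a functional assay on PC-3 cells (Homo sapiens) for cytotoxicity, read by sulforhodamine B assay (a higher number here means a weaker inhibitor of growth, a lower number a stronger inhibitor of growth), gives 5400 nM
compound 2, `COc1cccc(OC)c1OCCNCCOc1ccccc1OCc1cccc([N+](=O)[O-])c1`, in this assay gives 13200 nM
compound 3, `COc1cccc(OC)c1OCCNCCOc1ccccc1OCc1ccc([N+](=O)[O-])cc1`, in this assay gives 12000 nM

Compound 3 stands second highest of the three numbers. Its nearest neighbour is compound 2, with a 1.1-fold lower number from compound 2 to compound 3 (0.04 log units; within the scatter), so the two nitro compounds cannot be told apart. Against compound 1 the gap is larger, a 2.2-fold higher number from compound 1 to compound 3 (0.35 log units; beyond the scatter), and the same picture holds for a 2.4-fold higher number from compound 1 to compound 2 (0.39 log units; beyond the scatter).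

Compound 4, `COc1cccc(OC)c1OCCNCCOc1ccccc1OCc1ccc(OC(C)C)cc1`, is built from compound 3 by isopropoxy in place of nitro on an aromatic carbon. Within the data shown here, no measured step exchanges a nitro for an alkoxy group, so the bearing steps are only indirect: the two nitro isomers sit together, and the chlorophenyl compound sits modestly lower. Among the measured compounds shown here, the change to compound 4 therefore has no direct precedent, and no step beyond the scatter in this assay can be predicted with confidence. Compound 4 is estimated at 9000 nM, within 3500 nM to 25000 nM, which means an expected 1.3-fold lower number from compound 3 to compound 4 (0.12 log units; within the scatter).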

Compound 4, concentration for 50% growth inhibition: 2000 nM
Compound 4: the middle estimate sits 4.5-fold (0.65 log units) above what was measured; measured number below the stated range.
By their numbers in this assay, from the lowest: compound 4; then compound 1; then compounds 3 and 2 (each within the scatter of the next).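

In this assay, isopropoxy in place of nitro gives a 6.0-fold lower number from compound 3 to compound 4 (0.78 log units; beyond the scatter) and so shows that the number responds to the group carried at this aromatic carbon, which the two nitro isomers alone could not show. The 4-isopropoxyphenyl group also compares well with the other two aryl groups, with a 6.6-fold lower number from compound 2 to compound 4 (0.82 log units; beyond the scatter) and a 2.7-fold lower number from compound 1 to compound 4 (0.43 log units; beyond the scatter) so that compound 4 is the strongest inhibitor of growth of the four, with all its steps beyond the scatter. Nothing shown here gives a measured reason for this change.

As far as these compounds go, what stays open is whether a methoxy group, a longer alkoxy chain or a plain isopropyl group at this carbon would match isopropoxy, and so whether the step follows the oxygen or the branched carbons. Equally open, from the compounds shown here alone, is how an amine or a carboxylic acid would fare there.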